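Piperidine methyl removal on a quinazoline anilide series

The source may report more compounds than this note shows. Statements on the series, on what has been measured and on what is new or still open speak of the compounds shown alone.

Measured compounds in a functional assay on DLD-1 cells (Homo sapiens) for cytotoxicity, read by WST assay, with a stated time of 72 h; a lower number here means a stronger inhibitor, a higher number a weaker inhibitor:
compound 1 `COc1cc2c(Nc3nc4ccc(C(=O)Nc5c(C)cc(C)cc5C)cc4s3)ncnc2cc1OCCCN1CCC(C)CC1`: 7000 nM
compound 2 `COc1cc2c(Nc3nc4ccc(C(=O)Nc5c(C)cc(C)cc5C)cc4s3)ncnc2cc1OCCCN1CCCCC1C`: 5700 nM

Compound 2 sits alongside compound 1 on these two numbers: the step of a 1.2-fold lower number from compound 1 to compound 2 (0.09 log units; within the scatter) is the only measured one, and it separates nothing beyond the scatter. Compound 3 `COc1cc2c(Nc3nc4ccc(C(=O)Nc5c(C)cc(C)cc5C)cc4s3)ncnc2cc1OCCCN1CCCCC1` is not yet measured. Its change from compound 2 is hydrogen in place of methyl on a saturated ring carbon. Among the measured compounds shown here, the one measured step bears on it only loosely, since a 1.2-fold lower number from compound 1 to compound 2 (0.09 log units; within the scatter) moves the methyl around the ring rather than removing it, yet it shows that where the methyl sits on this ring leaves the cytotoxicity number essentially unchanged. For the measured compounds named here, no measured step shows the ring without a methyl. The expectation for compound 3 in this assay is therefore a step of a 1.1-fold higher number from compound 2 to compound 3 (0.02 log units; within the scatter) no larger than the scatter, in no particular direction. Compound 3 is estimated at 6000 nM, with a range from 2500 nM to 14000 nM.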

Compound 3, half-maximal inhibitory concentration: 24500 nM
Compound 3: the middle estimate sits 4.1-fold (0.61 log units) below what was measured; the measured number lies above the stated range.
By their numbers in this assay, from the lowest: compounds 2 and 1 (each within the scatter of the next); then compound 3.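

In this assay the methyl on the piperidine ring matters: a 4.3-fold higher number from compound 2 to compound 3 (0.63 log units; beyond the scatter) and a 3.5-fold higher number from compound 1 to compound 3 (0.54 log units; beyond the scatter) are both beyond the scatter, while the 2-methylpiperidin-1-yl and 4-methylpiperidin-1-yl compounds stay within the scatter of each other. Across these three compounds, having a methyl on the ring therefore counts for more than where it sits among the two placements shown, and the unsubstituted piperidin-1-yl of compound 3 is the weakest. Nothing available bears on why the number moves with this change.

Still open, from the compounds shown here alone, is whether the step is specific to methyl or would also follow from an ethyl or a hydroxyl on the same ring carbon. The compounds shown also leave open how 3-methylpiperidin-1-yl, or a morpholine in place of the piperidine, would compare.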